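Adding methoxy to the aryl ring of compound 3

The compounds below may be only part of what the source reports. "The series", "measured", "known", "first", "only" and "open" are said of these compounds alone.

Compound 3 (`Cc1nc(N2CCN(C)CC2)c2nc(-c3ccccc3C)n(C3CCOCC3)c2n1`) reads 18% in an ADME assay (liver) for metabolic stability, with Liver microsome (Homo sapiens) as the target, read by LC-MS, using microsomes, with a stated time of 30 min, tested at 4 uM (a higher number here means that more of the compound is left, a lower number that less of the compound is left), and stays within the scatter of compound 1 (`Cc1nc(N2CCN(C)CC2)c2nc(-c3ccccc3C#N)n(C3CCOCC3)c2n1`) with 20% as its reading. Compound 2 (`Cc1nc(N2CCN(C)CC2)c2nc(-c3ccccc3C3CC3)n(C3CCOCC3)c2n1`) stands clear of both with 33% as its reading.

Compound 4 (`COc1ccc(-c2nc3c(N4CCN(C)CC4)nc(C)nc3n2C2CCOCC2)c(C)c1`) carries methoxy in place of hydrogen on an aromatic carbon.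

Among the measured compounds shown here, three measured steps bear on this only indirectly, since none adds a methoxy. The step of a number 13 percentage points higher from compound 1 to compound 2 (beyond the scatter) and the step of a number 15 percentage points lower from compound 2 to compound 3 (beyond the scatter) are modest, while the step of a number 2 percentage points lower from compound 1 to compound 3 (within the scatter) shows no change beyond the scatter.

The expected step in this assay is a number 3 percentage points lower from compound 3 to compound 4 (within the scatter) and no shift beyond the scatter is expected. Compound 4 is estimated at 15% with an expected range from 5% to 30% for repeat readings.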

Compound 4, percent of the compound remaining: 21%
For compound 4 the middle estimate is 6 percentage points below the measured one; low and high end bracket the measured number.
By their numbers in this assay, from the lowest: compounds 3, 1 and 4 (each within the scatter of the next); then compound 2.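

In this assay methoxy in place of hydrogen, para to a large group, gives a number 3 percentage points higher from compound 3 to compound 4 (within the scatter) and so this position carries the added group with no shift beyond the scatter. The other comparisons give a number 1 percentage points higher from compound 1 to compound 4 (within the scatter) and a number 12 percentage points lower from compound 2 to compound 4 (beyond the scatter) and so compound 2 alone stays clear of the others. No supporting data bear on the cause of this result.

From the compounds shown here alone, whether an amine or a carboxylic acid on this same aromatic carbon would shift the reading beyond the scatter remains open. Also open, going by these compounds, is what methoxy would do on the 2-cyclopropylphenyl group of compound 2.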